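The source may report more compounds than this note shows. Statements on the series, on what has been measured and on what is new or still open speak of the compounds shown alone.

Within the data shown here, compound 1 `CN1CCC[C@H]1[C@H]1COc2c(N)cccc2O1` is one of three compounds measured in an assay on membranes from HEK293 cells for displacement of a labelled ligand from Neuronal acetylcholine receptor; alpha3/beta4 (Homo sapiens), with a stated time of 5 min (on this read-out lower numbers stand for stronger inhibition and higher numbers for weaker inhibition), and on that read-out compound 1 gives 13000 nM, the highest number of the three. Its nearest neighbour is compound 2 `CN1CCC[C@H]1[C@@H]1COc2c(N)cccc2O1`, which in this assay gives 3900 nM, and the step of a 3.3-fold lower number from compound 1 to compound 2 (0.52 log units; beyond the scatter) rests only on (the fact that compounds 1 and 2 differ only in the configuration as drawn). Furthest away stands compound 3 `CN1CCC[C@H]1[C@H]1COc2ccc(O)cc2O1`, which carries a hydroxy on the aromatic ring and in this assay gives 700 nM.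

Compound 4 `CN1CCC[C@H]1[C@H]1COc2c(O)cccc2O1` differs from compound 1 by hydroxy in place of amino on an aromatic carbon, on a six-membered aromatic ring of carbon only that is part of a fused system of two rings, ortho to a fused ring and meta to a fused ring. Among the measured compounds shown here, no measured step mirrors this exchange; the only step available, from compound 1 to compound 2, concerns configuration alone and says nothing about a change of substituent. For the measured compounds named here, compound 3 shows that a hydroxy somewhere on this ring can go with a far lower number, but the position differs and no step to compound 1 was measured.

He therefore expects compound 4 to give about 6000 nM in this assay, somewhere between 1500 nM and 25000 nM. That estimate corresponds to a 2.2-fold lower number from compound 1 to compound 4 (0.34 log units; beyond the scatter), a change not clearly beyond the scatter.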

Compound 4, inhibition constant: > 100000 nM
Compound 4: a limit, no number (the forecaster's own chance of this, stated with the estimate: 5%); at least 16-fold (1.22 log units) between middle value and limit.
By their numbers in this assay, from the lowest: compound 3; then compound 2; then compound 1. At a limit, above all of these: compound 4.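

Hydroxy in place of amino on this aromatic carbon, ortho to a fused ring and meta to a fused ring, brings an at least 7.6-fold higher number from compound 1 to compound 4 (0.88 log units; beyond the scatter), so at this position the two groups are not interchangeable in this assay. Compound 4 stands at > 100000 nM, which is a limit of the assay and not a number, so the full size of the step cannot be read: the limit of > 100000 nM in this assay, at which 1 of the 4 values shown sits. Among these compounds, compound 3, with its hydroxy at another place on the same ring, gives 700 nM, so the earlier compounds left a hydroxy looking acceptable on this ring, and only compound 4 shows that the place of the hydroxy matters.

The compounds shown leave open how a methoxy or a dimethylamino group on the same aromatic carbon would stand against amino and hydroxy, and whether an amino group at the place of the hydroxy of compound 3 would go with a number as low as that of compound 3. They also leave open whether the configuration effect seen in a 3.3-fold lower number from compound 1 to compound 2 (0.52 log units; beyond the scatter) carries over to compound 4, and they give no reason for the change at this position.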